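This account rests on a few compounds, and the source may have more. Where it says the series, first, only, none or still open, it means among the compounds named here.

Three compounds have been measured in an ADME assay on C8166 cells (Homo sapiens) for cytotoxicity, read by MTT assay; a higher number here means that more compound is tolerated, a lower number that less compound is tolerated:

Compound 1 `Cc1cc(S(N)(=O)=O)ccc1NC(=O)COc1ccc(Cl)cc1Oc1ccc2ccccc2c1Cl`: 40700 nM
Compound 2 `Cc1cc(S(N)(=O)=O)ccc1NC(=O)COc1ccc(Cl)cc1Oc1ccc2ccccc2c1Br`: 48100 nM
Compound 3 `Cc1cc(S(N)(=O)=O)ccc1NC(=O)COc1ccc(F)cc1Oc1ccc2cc(C#N)ccc2c1Br`: 35300 nM

Compounds 1 and 2 share one core and differ in a single place. Their difference is chloro in place of bromo on an aromatic carbon. In this assay the step of a 1.2-fold lower number from compound 2 to compound 1 (0.07 log units; within the scatter) is small, so the two values sit within the scatter of each other and no order between them can be read.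

Compound 3 carries a different core; how it differs from compound 2 is not broken down here. In this assay compound 3 gives 35300 nM, which lies within the scatter of both compound 1 and compound 2.

Compound 4 `Cc1cc(S(N)(=O)=O)ccc1NC(=O)COc1ccc(F)cc1Oc1ccc2cc(C#N)ccc2c1Cl` has not yet been measured in this assay. It differs from compound 3 by chloro in place of bromo on an aromatic carbon. This is the same change that separates compound 2 from compound 1, and it sits in the same surroundings in both pairs, as the two descriptions of the place agree word for word.

The expectation for compound 4 therefore rests on the pair already measured: because the step of a 1.2-fold lower number from compound 2 to compound 1 (0.07 log units; within the scatter) stayed within the scatter, the step of a 1.1-fold lower number from compound 3 to compound 4 (0.04 log units; within the scatter) is expected to be of similar size. Among the compounds with values here, compound 4 is estimated to give 32000 nM in this assay, with a range from 18000 nM to 60000 nM, the width reflecting that only one earlier example of this change is available.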

Compound 4, half-maximal cytotoxic concentration: 39700 nM
The estimate for compound 4 lay 1.2-fold (0.09 log units) below the measured number; low and high end bracket the measured number.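

In this assay, chloro in place of bromo on an aromatic carbon of the second core gives a 1.1-fold higher number from compound 3 to compound 4 (0.05 log units; within the scatter) and so leaves no order between the two compounds, just as on the first core. Set side by side, the two steps do not differ, so in this small set the exchange of these two halogens carries from one core to the other as a change too small to read: the same change on two cores in this assay, a 1.2-fold lower number (0.07 log units; within the scatter) from compound 2 to compound 1 and a 1.1-fold higher number (0.05 log units; within the scatter) from compound 3 to compound 4, 1.3-fold (0.12 log units) apart, within the scatter of two such steps. Within the data shown here, this shows that neither core gave a readable response to the change in this cytotoxicity read-out, but it gives no direction for the step, since each step lies within the scatter, and with only two cores it does not show that the same would hold on a further core or in another assay.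

The compounds shown leave open whether a group other than these two halogens on that aromatic carbon, such as methyl, methoxy or an amine, would also stay within the scatter of bromo and chloro. They also leave open whether exchanging the sulfonamide for another group, such as a carboxylic acid, would produce a step that could be read in this assay at all.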